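The source may hold more compounds than are shown below. What is called first, only, known or untested is meant among the compounds shown, and "the series" means these compounds.

Of the compounds shown here, three sharing one core have been measured in an ADME assay on microsomes from liver (Homo sapiens) for metabolic stability, with a stated time of 30 min, tested at 1 uM; on this read-out lower numbers stand for a shorter-lived compound and higher numbers for a longer-lived compound. Compound 1, `COc1ccc2[nH]c(C(=O)N3CC(=O)N(Cc4ccccc4)[C@@H](CN4CCCCC4)C3)cc2c1`, gives 0.283 h. Compound 2, `COc1ccc2[nH]c(C(=O)N3CC(=O)N(Cc4ccccc4)[C@@H](CN4CCC(C)CC4)C3)cc2c1`, gives 0.267 h. Compound 3, `COc1ccc2[nH]c(C(=O)N3CC(=O)N(Cc4ccccc4)[C@@H](N4CCc5ccccc54)C3)cc2c1`, gives 0.25 h. The three numbers sit close together: the step of a 1.1-fold lower number from compound 1 to compound 2 (0.03 log units; within the scatter), the step of a 1.1-fold lower number from compound 1 to compound 3 (0.05 log units; within the scatter) and the step of a 1.1-fold lower number from compound 2 to compound 3 (0.03 log units; within the scatter) all lie within the scatter, so compound 3 cannot be set apart from the other two on this read-out.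

Compound 4, `COc1ccc2[nH]c(C(=O)N3CC(=O)N(Cc4ccccc4)[C@@H](COc4ccc(F)cc4)C3)cc2c1`, differs from compound 3 in one place: (4-fluorophenoxy)methyl in place of 2,3-dihydro-1H-indol-1-yl on a saturated ring carbon. Among the measured compounds shown here, the steps that bear on this are those already seen at the same ring carbon, where exchanging one group for another of similar size, as in a 1.1-fold lower number from compound 1 to compound 3 (0.05 log units; within the scatter) and a 1.1-fold lower number from compound 2 to compound 3 (0.03 log units; within the scatter), left this assay unchanged beyond the scatter. By the same token the step of a 1.1-fold higher number from compound 3 to compound 4 (0.03 log units; within the scatter) is expected to stay within the scatter. Compound 4 is therefore estimated to give 0.27 h in this assay, with a likely range from 0.14 h to 0.55 h.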

Compound 4, half-life: 0.317 h
Beside the measured number, compound 4's estimate is 1.2-fold (0.07 log units) below it, within the range that was stated.
By their numbers in this assay, from the lowest: compounds 3, 2, 1 and 4 (each within the scatter of the next).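

In this assay, among the compounds shown here, the earlier compounds only exchanged groups that carry a nitrogen on this saturated ring carbon, and compound 4 shows that (4-fluorophenoxy)methyl, which brings oxygen and fluorine and no nitrogen, also leaves the half-life within the scatter of all three others (a 1.3-fold higher number from compound 3 to compound 4 (0.10 log units; within the scatter)) (a 1.2-fold higher number from compound 2 to compound 4 (0.07 log units; within the scatter)) (a 1.1-fold higher number from compound 1 to compound 4 (0.05 log units; within the scatter)). The four compounds therefore cannot be told apart on this read-out, even though the group at this position has changed in its atoms and in its rings. Nothing measured here gives a reason for this sameness.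

As far as these compounds go, whether a carboxylic acid, a primary amine or a longer chain on this ring carbon would move the half-life beyond the scatter remains open. So does whether exchanging the benzyl group on the neighbouring ring atom would do so.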